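A few compounds are considered here, and "the series" means these few. Any claim that something is new, unique, unknown or untested is made for them only; others in the source may bear on it.

Compound 1 `C=C1[C@H](C)CCC[C@]1(C)CC/C(C)=C/CC1=C(O)C(=O)C=C(N[C@@H](C(=O)O)[C@H](C)O)C1=O`: > 10 ug/mL
Compound 2 `CC1=CCC[C@](C)(CC/C(C)=C/CC2=C(O)C(=O)C=C(N[C@@H](CO)C(=O)O)C2=O)[C@@H]1C`: > 10 ug/mL
Compound 3 `C=C1[C@H](C)CCC[C@]1(C)CC/C(C)=C/CC1=C(O)C(=O)C=C(N[C@@H](C(=O)O)[C@@H](C)O)C1=O`: > 10 ug/mL

These entries all come from an ADME assay on KB cells (Homo sapiens) for cytotoxicity, with a stated time of 48 h (on this read-out higher numbers stand for weaker inhibition and lower numbers for stronger inhibition), and each one is a limit of the assay, not a number. Compound 3 therefore has no exact place on the scale, and it shares the limit of > 10 ug/mL in this assay, at which 3 of the 3 values shown sit, with the other two.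

Compound 4 `C=C1[C@H](C)CCC[C@]1(C)CC/C(C)=C/CC1=C(O)C(=O)C=C(N[C@@H](CO)C(=O)O)C1=O` has 1-carboxy-2-hydroxyethyl in place of 1-carboxy-2-hydroxypropyl on an amine nitrogen, and the counted change is 1-carboxy-2-hydroxyethyl in place of 1-carboxy-2-hydroxypropyl on an amine nitrogen.

Among the compounds with values here, the only measured step nearby is a step that the two limits leave unreadable from compound 1 to compound 3, and it involves (the fact that compounds 1 and 3 differ only in the configuration as drawn), so it does not test this change. Compound 2 already carries 1-carboxy-2-hydroxyethyl on an amine nitrogen, though its core is drawn differently, and it gives > 10 ug/mL, also a limit.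

With no readable step to build on, no shift beyond the scatter is expected in this assay, in either direction, and another limit is the likeliest report. The estimated step is a step that the limit leaves unreadable from compound 3 to compound 4. Compound 4 is expected to read 15 ug/mL, with an estimated range from 7 ug/mL to 40 ug/mL.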

Compound 4, half-maximal inhibitory concentration: > 10 ug/mL
Compound 4 ended at the assay's limit; the forecaster's own chance of this, stated with the estimate: 85%; the middle value lies beyond the limit too.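

In this assay compound 4 gives > 10 ug/mL which is a limit of the assay and not a number. Its steps from compound 1, compound 2 and compound 3 therefore cannot be read. The compounds shown leave open whether 1-carboxy-2-hydroxyethyl and 1-carboxy-2-hydroxypropyl differ in cytotoxicity at all.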